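The compounds below may be only part of what the source reports. "The series", "measured", "known", "first", "only" and "open" are said of these compounds alone.

- compound 1 `CCNc1nc(SCc2nc3ccccc3[nH]2)nc(-c2ccccc2)c1C#N`: 2.63 nM
- compound 2 `N#Cc1c(NC(N)=O)nc(SCc2nc3ccccc3[nH]2)nc1-c1ccccc1`: 3.37 nM

In a functional assay on U-937 cells (Homo sapiens) for cytotoxicity, read by MTT assay, with a stated time of 3 days (a lower number here means a stronger inhibitor, a higher number a weaker inhibitor), compound 2 gives 3.37 nM, which cannot be told apart from the value of compound 1. For the measured compounds named here, the one measured step is a 1.3-fold higher number from compound 1 to compound 2 (0.11 log units; within the scatter), and it swapped carbamoyl in place of ethyl on a nitrogen on an aromatic ring.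

Compound 3 `CN1CCN(c2nc(SCc3nc4ccccc4[nH]3)nc(-c3ccccc3)c2C#N)CC1` has not been measured. It has 4-methylpiperazin-1-yl in place of ureido on an aromatic carbon, ortho to a cyano group: 4-methylpiperazin-1-yl in place of ureido on an aromatic carbon. Going by the values given here, this is a larger swap in the same part of the molecule, and no measured compound carries such a ring there. With only the small step of a 1.3-fold higher number from compound 1 to compound 2 (0.11 log units; within the scatter) as a guide, no shift beyond the scatter is expected in this assay, though the uncertainty is wide. The estimated change is a 1.2-fold higher number from compound 2 to compound 3 (0.07 log units; within the scatter). For compound 3 the expected value is 4 nM, with an estimated range from 1 nM to 20 nM.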

Compound 3, half-maximal inhibitory concentration: 6.75 nM
Compound 3: the middle estimate sits 1.7-fold (0.23 log units) below what was measured; low and high end bracket the measured number.
By their numbers in this assay, from the lowest: compounds 1, 2 and 3 (each within the scatter of the next, the first and the last beyond it).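

Placing a ring on this aromatic carbon, ortho to a cyano group, is a new kind of change, and in this assay the 4-methylpiperazin-1-yl group still stays within the scatter when set against the ureido group (a 2.0-fold higher number from compound 2 to compound 3 (0.30 log units; within the scatter)). Set against the ethylamino group, the same ring gives the first step at this position that passes the scatter (a 2.6-fold higher number from compound 1 to compound 3 (0.41 log units; beyond the scatter)), a modest loss that shows the position accepts a ring at only a small cost in this assay. Nothing available explains the size of this step.

The compounds shown carry only this one ring here, so it remains open whether a morpholine or a piperazine without the methyl group would read the same. From the compounds shown here alone, a plain primary amine or a longer alkyl chain at this position also remains open.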